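Swapping Bromine for a Fluorophenyl Ring: What to Expect

A few compounds are considered here, and "the series" means these few. Any claim that something is new, unique, unknown or untested is made for them only; others in the source may bear on it.

Compound 1 has the structure `O=C(Nc1cccc(F)c1)c1cc(=O)[nH]c2cc(Br)ccc12` and in a functional assay on KYSE-70 cells for antiproliferative activity against KYSE-70 cell line (Homo sapiens), read by MTT assay, with a stated time of 72 h (on this read-out lower numbers stand for stronger inhibition and higher numbers for weaker inhibition), compound 1 gives 8900 nM.
Compound 2 has the structure `O=C(Nc1cccc(Cl)c1)c1cc(=O)[nH]c2cc(Br)ccc12` and in this assay compound 2 reaches only the assay limit of > 20000 nM, not a number.
Compound 3 has the structure `O=C(Nc1cccc(OC(F)(F)F)c1)c1cc(=O)[nH]c2cc(Br)ccc12` and in this assay compound 3 likewise reaches only the limit of > 20000 nM.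

Within the data shown here, compound 1 therefore stands as the only compound with a real number; the other two sit at a limit, as noted in the limit of > 20000 nM in this assay, at which 2 of the 3 values shown sit. Both measured steps change the group on the amide-bearing ring: an at least 2.2-fold higher number from compound 1 to compound 2 (0.35 log units; beyond the scatter) and an at least 2.2-fold higher number from compound 1 to compound 3 (0.35 log units; beyond the scatter). Neither touches the other end of the shared core, where compound 4, with the structure `O=C(Nc1cccc(F)c1)c1cc(=O)[nH]c2cc(-c3ccccc3F)ccc12`, differs from compound 1 by 2-fluorophenyl in place of bromo on an aromatic carbon. Among the measured compounds shown here, no measured step therefore bears directly on this change, and what it will do in this assay is unknown from these data alone. For the measured compounds named here, since compound 1 gives 8900 nM and the only change made here exchanges one small group for a larger ring, compound 4 is estimated at 6000 nM, between 1500 nM and 20000 nM. This estimate means an expected step of a 1.5-fold lower number from compound 1 to compound 4 (0.17 log units; within the scatter).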

Compound 4, half-maximal inhibitory concentration: > 20000 nM
Compound 4: no number, only a limit; the forecaster's own chance of this, stated with the estimate: 25%; middle value at least 3.3-fold (0.52 log units) from the limit.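

Among these compounds, every earlier step changed the amide-bearing ring, so this is the first measurement at the other end of the shared core, and it shows that this position also affects the read-out in this assay: putting 2-fluorophenyl in place of bromo gives an at least 2.2-fold higher number from compound 1 to compound 4 (0.35 log units; beyond the scatter). Compound 4 gives > 20000 nM, which is a limit of the assay and not a number, so the step has a smallest size but no known full size. Compound 1 therefore remains the only compound with a real number, and the steps among the compounds at the limit cannot be read: the limit of > 20000 nM in this assay, at which 3 of the 4 values shown sit.

With only one replacement for bromo shown, the result cannot separate the effect of removing bromo from that of adding this particular ring. An amine, a methyl group or a phenyl ring without fluorine at the same position would help to show whether any group other than bromo keeps a measurable value, and whether the fluorine on the new ring matters to the result.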